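The source may hold more compounds than are shown below. What is called first, only, known or untested is meant among the compounds shown, and "the series" means these compounds.

Measured so far in an ADME assay on cells (Hepatocyte, Rattus norvegicus) for metabolic stability, using equilibrium dialysis; a lower number here means slower removal, a higher number faster removal of the compound:
- compound 1 `CC(=O)N[C@@H]1CCC[C@H](C(=O)Nc2cc(-c3cnc4n3CCC4)c(Cl)cn2)C1`: 19 uL/min
- compound 2 `CC(=O)N[C@@H]1CCC[C@H](C(=O)Nc2cc(-c3cnn4c3CCCCC4)c(Cl)cn2)C1`: 51 uL/min
- compound 3 `CC(=O)N[C@@H]1CCC[C@H](C(=O)Nc2cc(-c3cnn4c3CC(C)(C)C4)c(C#N)cn2)C1`: 47 uL/min

Compound 2 gives the highest of the three numbers; compound 3 sits within the scatter of it, while compound 1 lies a clear step below. For the measured compounds named here, the one step measured within the shared core is a 2.7-fold higher number from compound 1 to compound 2 (0.43 log units; beyond the scatter).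

Compound 4 `CC(=O)N[C@@H]1CCC[C@H](C(=O)Nc2cc(-c3cnc4n3CC(C)(C)C4)c(Cl)cn2)C1` has not yet been measured in this assay. It differs from compound 2 in one place: a group of 10 heavy atoms (8 carbon, 2 nitrogen; one five-membered non-aromatic ring with 1 hetero atom, one five-membered aromatic ring with 2 hetero atoms) in place of a group of 10 heavy atoms (8 carbon, 2 nitrogen; one five-membered aromatic ring with 2 hetero atoms, one seven-membered non-aromatic ring with 1 hetero atom), on an aromatic carbon

Going by the values given here, the step bearing on this change is the one from compound 1 to compound 2, which went the other way: a seven-membered non-aromatic ring replaced a five-membered one and the number rose modestly. Compound 4 returns to a five-membered non-aromatic ring, so part of that step is expected to reverse. Among the compounds with values here, compound 1 and compound 4 share the fused ring pattern but no step between them is measured, and compound 4 carries two further carbons in its non-aromatic ring; compound 3, which also carries such a ring, gives a number close to compound 2, so a full return to the value of compound 1 is not expected.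

For compound 4 the expected step is a 1.6-fold lower number from compound 2 to compound 4 (0.20 log units; within the scatter), a modest lowering at the edge of the scatter. Compound 4 is therefore estimated at 32 uL/min, with a range from 16 uL/min to 64 uL/min.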

Compound 4, intrinsic clearance in a liver preparation (reported as CLH), per the amount of preparation that the assay uses: 28 uL/min
The estimate for compound 4 lay 1.1-fold (0.06 log units) above the measured number, within the range that was stated.
By their numbers in this assay, from the lowest: compounds 1, 4, 3 and 2 (each within the scatter of the next, the first and the last beyond it).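

In this assay, at the aromatic carbon opposite the ring nitrogen, rejoining the same atoms into a different pair of rings gives a 1.8-fold lower number from compound 2 to compound 4 (0.26 log units; within the scatter), so this exchange does not separate the two compounds. For the compounds shown here, the group of 10 heavy atoms in place of the group of 8 heavy atoms gives a 1.5-fold higher number from compound 1 to compound 4 (0.17 log units; within the scatter), which again does not separate the two compounds, so compound 4 stands within the scatter of both ends of a 2.7-fold higher number from compound 1 to compound 2 (0.43 log units; beyond the scatter), the only step here beyond it; neither the heavy-atom count nor the size of the non-aromatic ring can be singled out as what carries that step. No measurement is available that would account for any of these steps.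

The compounds shown hold no pair that differs only in nitrile against chloro, so the part played by that group in this series stays open. Also open, on these data alone, is whether an amine or a hydroxyl group on the non-aromatic ring at this position would give a step beyond the scatter, in either direction.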